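Hydroxyurea series: methyl on the terminal amide nitrogen

The compounds below may be only part of what the source reports. "The series", "measured", "known", "first", "only" and "open" are said of these compounds alone.

Compound 1 `NC(=O)N(O)CC1=Cc2cc(Oc3ccccc3)ccc2OCC1` and compound 2 `NC(=O)N(O)CC1=Cc2cc(Oc3ccc(F)cc3)ccc2OCC1` share one core and differ only by a fluoro on an aromatic carbon. In an assay on isolated protein (Cavia porcellus) for inhibition of Polyunsaturated fatty acid 5-lipoxygenase (Homo sapiens) (a lower number here means a stronger inhibitor, a higher number a weaker inhibitor), compound 1 gives 89 nM, and compound 2 gives 91 nM. Going by the values given here, the single measured step, a 1.0-fold higher number from compound 1 to compound 2 (0.01 log units; within the scatter), lies within the scatter, so compound 2 holds the higher of the two numbers without being separated from compound 1 in any meaningful way.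

Compound 3 `CNC(=O)N(O)CC1=Cc2cc(Oc3ccc(F)cc3)ccc2OCC1` departs from compound 2 at a different site: methyl in place of hydrogen on an amide-type nitrogen. Among the compounds with values here, no measured step in this set touches the amide-type nitrogen; the only step available, a 1.0-fold higher number from compound 1 to compound 2 (0.01 log units; within the scatter), concerns the aromatic fluoro and carries no information about substitution on the hydroxyurea end. Within the data shown here, the direction of the change therefore rests on no measured precedent here, and a modest rise in the number, possibly still within the scatter, is the working expectation. Compound 3 is estimated at 160 nM, with a range from 50 nM to 500 nM. The expected step is a 1.8-fold higher number from compound 2 to compound 3 (0.25 log units; within the scatter).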

Compound 3, half-maximal inhibitory concentration: 100 nM
Compound 3: the middle estimate sits 1.6-fold (0.20 log units) above what was measured; the range from low to high includes it.
By their numbers in this assay, from the lowest: compounds 1, 2 and 3 (each within the scatter of the next).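

Methyl in place of hydrogen on the amide-type nitrogen gives, in this assay, a 1.1-fold higher number from compound 2 to compound 3 (0.04 log units; within the scatter), the first reading at this end of the hydroxyurea, since the earlier step concerned only the aromatic fluoro. One added carbon on this nitrogen, with the amino group becoming methylamino, therefore does not separate compound 3 from compound 2, and the hydrogen on this nitrogen is not required to keep the number in the range of compound 2, which stands at 91 nM. With a 1.0-fold higher number from compound 1 to compound 2 (0.01 log units; within the scatter) also within the scatter, neither of the two single changes shown so far moves the number measurably in this assay, and nothing available here accounts for that outcome.

As far as these compounds go, what remains open is whether the same nitrogen accepts more than one methyl: an ethyl group, a longer chain, a second methyl on that nitrogen or a phenyl ring could each reveal a limit that a single methyl does not reach. Also open, from the compounds shown here alone, is whether the methyl step reads the same on the core of compound 1, without the fluoro on the aromatic carbon.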